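Notes on the amine substituent change, compound 2 to compound 4

The source may hold more compounds than are shown below. What is called first, only, known or untested is meant among the compounds shown, and "the series" means these compounds.

Measured so far:
compound 1 `O=C(NCc1ccc(F)cc1)c1nc(NCCO)c2cccnc2c1O` in a functional assay on HCT-116 cells (Homo sapiens) for cytotoxicity, read by MTT assay, with a stated time of 72 h; on this read-out lower numbers stand for stronger inhibition and higher numbers for weaker inhibition: "not determined" (no result reported)
compound 2 `C[C@@H](Nc1c(C(=O)NCc2ccc(F)cc2)nc(Br)c2cccnc12)c1ccccc1`: > 20000 nM
compound 3 `C[C@H](Nc1c(C(=O)NCc2ccc(F)cc2)nc(Br)c2cccnc12)c1ccccc1`: > 20000 nM

In this assay compound 2 gives > 20000 nM, which is a limit of the assay and not a number. Compound 3 likewise gives > 20000 nM, again a limit. The step that the two limits leave unreadable from compound 2 to compound 3 cannot be read because of the limit of > 20000 nM in this assay, at which 2 of the 3 values shown sit; the two compounds differ only in configuration, as the fact that compounds 2 and 3 differ only in the configuration as drawn states. Compound 1 has no result.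

Compound 4 `COC(=O)CNc1c(C(=O)NCc2ccc(F)cc2)nc(Br)c2cccnc12` differs from compound 2 by (methoxycarbonyl)methyl in place of 1-phenylethyl on a nitrogen on an aromatic ring. Within the data shown here, no measured step touches this kind of change; the only step available is the unreadable one between the two configurations. No direction can therefore be expected beyond the scatter, and compound 4 is expected to sit again at the limit, estimated at 25000 nM within 8000 nM to 60000 nM. The expected step that the limit leaves unreadable from compound 2 to compound 4 is accordingly estimated as essentially none.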

Compound 4, half-maximal inhibitory concentration: > 10000 nM
Compound 4 ended at the assay's limit; the forecaster's own chance of this, stated with the estimate: 70%; the middle value lies beyond the limit too.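

Compound 4 gives [ > 10000 nM ], a limit and not a number. The steps from compound 2 and from compound 3 to compound 4 cannot be read. Open remains whether (methoxycarbonyl)methyl in place of 1-phenylethyl shifts the read-out at all.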